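A Bromo for Hydroxy Swap on a Benzamide Cap

The compounds below may be only part of what the source reports. "The series", "measured", "known", "first", "only" and "open" are said of these compounds alone.

compound 1 `Nc1cc(O)ccc1NC(=O)c1ccc(CNc2nccc(-c3cccnc3)n2)cc1` — > 20000 nM
compound 2 `CC(=O)N1C(NCc2ccc(C(=O)Nc3ccccc3N)cc2)=NC(=O)C1Cc1ccccc1` — > 20000 nM
compound 3 `Nc1ccccc1NC(=O)c1ccc(CNC2=NC[C@@H](c3ccccc3)S2)cc1` — "not determined" (no result reported)

In an assay on isolated protein for inhibition of protein deacetylase HDAC6 (Homo sapiens), read by fluorescence, with stated times of 3 h and 60 min (on this read-out lower numbers stand for stronger inhibition and higher numbers for weaker inhibition), compound 1 gives > 20000 nM, which is a limit of the assay and not a number. Compound 2 likewise gives > 20000 nM, again a limit. For compound 3 the outcome in this assay is "not determined" (no result reported). Compound 1 therefore stands at the limit together with compound 2 (the limit of > 20000 nM in this assay, at which 2 of the 3 values shown sit), and none of the three compounds carries a single number from which a step could be sized.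

Compound 4 `Nc1cc(Br)ccc1NC(=O)c1ccc(CNc2nccc(-c3cccnc3)n2)cc1` differs from compound 1 in one place: bromo in place of hydroxy on an aromatic carbon, meta to an amino group and para to a large group. Among the compounds with values here, no step between measured compounds is available to show what such a change does in this assay, so the only footing is the limit at which compound 1 sits. On that footing a step from compound 1 to compound 4 of a number no higher from compound 1 to compound 4 (the limit leaves the size open) is expected, that is, none beyond the scatter. Compound 4 is therefore expected to come in around 20000 nM, in the range from 5000 nM to 60000 nM, most likely reported as a limit rather than a number.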

Compound 4, half-maximal inhibitory concentration: > 20000 nM
Compound 4 gave a limit, no number (the forecaster's own chance of this, stated with the estimate: 75%); the middle value sits exactly at the limit.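

In this assay compound 4 gives > 20000 nM, a limit and not a number. Compound 1 also stands at a limit, so no step from compound 1 to compound 4 can be read: the limit of > 20000 nM in this assay, at which 3 of the 4 values shown sit.

The compounds shown leave open whether bromo in place of hydroxy on an aromatic carbon changes inhibition at all, and what single number any of them would give.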